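This account rests on a few compounds, and the source may have more. Where it says the series, first, only, none or still open, it means among the compounds named here.

Measured compounds:

Compound 1, `O=[N+]([O-])c1ccc(CN2CCC(n3cc(CC(OCc4cc(-c5ccccc5)no4)c4ccc(Br)cc4)nn3)CC2)cc1`, in a functional assay on MCF7 cells (Homo sapiens) for cytotoxicity, with a stated time of 48 h (a higher number here means a weaker inhibitor, a lower number a stronger inhibitor), gives only a limit, > 25000 nM.
Compound 2, `O=[N+]([O-])c1ccc(CN2CCC(n3cc(CC(OCc4cc(-c5ccc(F)cc5)no4)c4ccc(Br)cc4)nn3)CC2)cc1`, gives 7000 nM.
Compound 3, `N#Cc1ccc(-c2cc(COC(Cc3cn(C4CCN(Cc5ccc([N+](=O)[O-])cc5)CC4)nn3)c3ccc(Br)cc3)on2)cc1`, gives 3000 nM.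

Compound 3 holds the lowest of the two numbers; its nearest neighbour is compound 2, separated by a 2.3-fold lower number from compound 2 to compound 3 (0.37 log units; beyond the scatter). Compound 4, `O=[N+]([O-])c1ccc(CN2CCC(n3cc(CC(OCc4cc(-c5cccc(Br)c5)no4)c4ccc(Br)cc4)nn3)CC2)cc1`, differs from compound 3 by 3-bromophenyl in place of 4-cyanophenyl on an aromatic carbon. Going by the values given here, the steps that bear on this are an at least 3.5-fold lower number from compound 1 to compound 2 (0.55 log units; beyond the scatter) and an at least 8.3-fold lower number from compound 1 to compound 3 (0.92 log units; beyond the scatter), both gains when a group was placed on this phenyl, though compound 1 sits at a limit (the limit of > 25000 nM in this assay, at which 1 of the 3 values shown sits). A 3-bromophenyl has not been measured, so the direction is uncertain; the only halogen here, the fluoro of compound 2, gave a higher number than compound 3 beyond the scatter. For compound 4 the expected step is a 2.0-fold higher number from compound 3 to compound 4 (0.30 log units; within the scatter), giving an estimate of 6000 nM with a range from 2500 nM to 15000 nM.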

Compound 4, half-maximal inhibitory concentration: 6000 nM
Estimate against measurement, compound 4: no gap at the digits printed; measured number inside the range.
By their numbers in this assay, from the lowest: compounds 3, 4 and 2 (each within the scatter of the next, the first and the last beyond it). At a limit, above all of these: compound 1.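

A 3-bromophenyl also gives a gain over the plain phenyl, an at least 4.1-fold lower number from compound 1 to compound 4 (0.61 log units; beyond the scatter), so the gain at this position is not confined to the 4-fluorophenyl and 4-cyanophenyl groups. Compound 1 gives only a limit, > 25000 nM. Compound 4 cannot be told apart from either of those two compounds, a 2.0-fold higher number from compound 3 to compound 4 (0.30 log units; within the scatter) and a 1.2-fold lower number from compound 2 to compound 4 (0.07 log units; within the scatter), as both steps lie within the scatter.

From the compounds shown here alone, it remains open whether a bromo elsewhere on this phenyl would give a similar number. Going by these compounds, whether an amine or a carboxylic acid on this ring would keep the gain also remains open.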